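A few compounds are considered here, and "the series" means these few. Any claim that something is new, unique, unknown or untested is made for them only; others in the source may bear on it.

Four compounds share a central ring bearing a five-membered heteroaromatic group, and differ in what is attached on either side. Compound 1 `O=C(C1CCC(C(F)(F)F)CC1)N1CC(c2nc(-c3cccc(F)c3)no2)C1` and compound 2 `Cc1cccc(-c2noc(C3CN(C(=O)C4CCC(C(F)(F)F)CC4)C3)n2)c1` carry an amide to a ring bearing a trifluoromethyl group; compound 3 `Cc1ccc(S(=O)(=O)N2CC(c3nc(-c4cccc(C)c4)no3)C2)cc1` and compound 4 `Cc1cccc(-c2noc(C3CN(S(=O)(=O)c4ccc(F)cc4)C3)n2)c1` carry a sulfonamide to an aromatic ring instead. How the core of compound 2 and the core of compound 3 differ is not broken down here.

In an assay on HEK293 cells for positive allosteric modulation of metabotropic glutamate receptor 5 (Homo sapiens), read by FLIPR (a higher number here means that more compound is needed for the effect, a lower number that less compound is needed), compound 1 gives 680 nM, and compound 2 gives 1000 nM. The difference between them is fluoro in place of methyl on an aromatic carbon, and the step is a 1.5-fold lower number from compound 2 to compound 1 (0.17 log units; within the scatter). For compound 3 only a limit was recorded in this assay, > 10000 nM, so no number is known for it; (the limit of > 10000 nM in this assay, at which 1 of the 3 values shown sits).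

Compound 4 has not yet been measured. Its difference from compound 3 is fluoro in place of methyl on an aromatic carbon. This is the same kind of change as from compound 2 to compound 1, but not the same: in the measured pair the new group sits meta to a large group, whereas here it sits para to a large group. The measured step stayed within the scatter, and compound 3 sits at the limit, so the estimated step from compound 3 to compound 4 in this assay is a step that the limit leaves unreadable from compound 3 to compound 4, and the estimate for compound 4 is 15000 nM, with a range from 5000 nM to 50000 nM; most likely the result will again be only a limit.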

Compound 4, half-maximal effective concentration: > 10000 nM
Compound 4 ended at the assay's limit; the forecaster's own chance of this, stated with the estimate: 70%; the middle value is on the limit's open side.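

In this assay, compound 3 and compound 4 both ended at a limit of the assay rather than at a number, so the step between them cannot be read: the limit of > 10000 nM in this assay, at which 2 of the 4 values shown sit.

The compounds shown leave open what number either compound would give, and whether going from 4-methylphenyl to 4-fluorophenyl on the sulfonamide changes that number at all.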